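The compounds below may be only part of what the source reports. "The series", "measured", "known", "first", "only" and "open" are said of these compounds alone.

Measured compounds:
Compound 1 `CC1=C(C)C(=O)C(CCCCCCCCCCn2cc(C[C@H](O)COCCOC[C@@H](O)Cc3ccc(-c4ccccc4)cc3)nn2)=C(C)C1=O` gives 900 nM in a functional assay on HCT-116 cells (Homo sapiens) for inhibition, read by MTT assay, with a stated time of 72 h; a higher number here means a weaker inhibitor of growth, a lower number a stronger inhibitor of growth.
Compound 2 `COC1=C(C)C(=O)C(CCCCCCCCCCn2cc(C[C@H](O)COCCOC[C@@H](O)Cc3ccc(-c4ccccc4)cc3)nn2)=C(C)C1=O` gives 4000 nM in this assay.
Compound 3 `O[C@H](COCCOC[C@@H](O)Cc1cn(-c2cccs2)nn1)Cc1ccc(-c2ccccc2)cc1` gives 33400 nM in this assay.

Compound 3 stands highest of the three numbers in this assay, and its distance from both other compounds lies beyond the scatter, so it is the weakest inhibitor of growth among them; compound 2 is the nearer of the two and compound 1 the further.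

Among the compounds with values here, the one measured step, a 4.4-fold higher number from compound 1 to compound 2 (0.65 log units; beyond the scatter), concerns a change on a part of the shared core of compounds 1 and 2 that compound 3 does not carry, so it does not bear directly on the step to compound 4 `O=c1[nH]c2ccc(-n3cc(C[C@H](O)COCCOC[C@@H](O)Cc4ccc(-c5ccccc5)cc4)nn3)cc2s1`. That step is a group of 10 heavy atoms (7 carbon, 1 nitrogen, 1 oxygen, 1 sulfur; one five-membered aromatic ring with 2 hetero atoms, one six-membered aromatic ring of carbon only) in place of a group of 5 heavy atoms (4 carbon, 1 sulfur; one five-membered aromatic ring with 1 hetero atom), on an aromatic nitrogen. Within the data shown here, with no measured step of this kind at hand, the direction and size of the change in this assay are open; the larger group entering in place of the thiophen-2-yl could move the number either way, and a step within the scatter is as plausible as a modest one.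

Compound 4 is therefore expected to give about 20000 nM in this assay, estimated to lie between 5000 nM and 80000 nM. The expected step is a 1.7-fold lower number from compound 3 to compound 4 (0.22 log units; within the scatter).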

Compound 4, concentration for 50% growth inhibition: 9200 nM
Estimate against measurement, compound 4: 2.2-fold (0.34 log units) above, and the stated range covers the measured number.
By their numbers in this assay, from the lowest: compound 1; then compound 2; then compound 4; then compound 3.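

In this assay, within the data shown here, the aromatic nitrogen responds to a change of group: putting the larger group with two aromatic rings in place of the thiophen-2-yl gives a 3.6-fold lower number from compound 3 to compound 4 (0.56 log units; beyond the scatter), the first measured step at this position and a modest one that lies beyond the scatter. The change alters several things at once, adding heavy atoms, a second aromatic ring, a double bond outside aromatic rings and a hydrogen-bond donor that the thiophen-2-yl lacks, so this single step cannot be assigned to any one of them. No measurement offered here explains the step.

The compounds shown leave open whether a plain phenyl on the same nitrogen would give a similar step, or whether the step needs the carbonyl and the amide hydrogen of the entering group. They also leave open whether a carboxylic acid or an amine on that aromatic group would lower the number further, given that compound 4 gives 9200 nM while compound 1 gives 900 nM.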